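Methoxy in place of methylsulfanyl on a shared nucleoside core

This account rests on a few compounds, and the source may have more. Where it says the series, first, only, none or still open, it means among the compounds named here.

Compound 3 `CSCc1ncnc2c1ncn2[C@@H]1O[C@H](CO)[C@@H](O)[C@H]1O` gives > 100000 nM in a functional assay on Huh-7 cells (Homo sapiens) for cytotoxicity, read by MTT assay, with a stated time of 3 days (a higher number here means that more compound is tolerated, a lower number that less compound is tolerated), which is a limit of the assay rather than a number. Compound 1 `[N-]=[N+]=NCc1ncnc2c1ncn2[C@@H]1O[C@H](CO)[C@@H](O)[C@H]1O` gives > 250000 nM in this assay, again a limit. Compound 2 `OC[C@H]1O[C@@H](n2cnc3c(COc4ccccn4)ncnc32)[C@H](O)[C@@H]1O` gives > 250000 nM, also a limit.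

Compound 3 thus stands at a limit, as do the two other values shown: the limit of > 100000 nM in this assay, at which 1 of the 3 values shown sits, and (the limit of > 250000 nM in this assay, at which 2 of the 3 values shown sit). The steps a step that the two limits leave unreadable from compound 1 to compound 2, a step that the two limits leave unreadable from compound 1 to compound 3 and a step that the two limits leave unreadable from compound 2 to compound 3 are therefore not readable in size. Compound 4 `COCc1ncnc2c1ncn2[C@@H]1O[C@H](CO)[C@@H](O)[C@H]1O` differs from compound 3 in one place: methoxy in place of methylsulfanyl on a saturated chain carbon bound to an aromatic carbon. Going by the values given here, no measured step gives a readable size for this change, so no step beyond the scatter is expected. Compound 4 is estimated at 150000 nM, between 50000 nM and 500000 nM. The expected step that the limit leaves unreadable from compound 3 to compound 4 is essentially none.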

Compound 4, half-maximal cytotoxic concentration: > 100000 nM
Compound 4 ended at the assay's limit (the forecaster's own chance of this, stated with the estimate: 85%); the middle value lies beyond the limit too.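

In this assay, going by these compounds alone, compound 4, like compound 1, compound 2 and compound 3, gives a limit and not a number, so no step involving compound 4 can be read in size. The compounds shown leave open at what concentration any of them becomes toxic to these cells.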